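Swapping the amide aryl group of a potent cytotoxic compound

The source may report more compounds than this note shows. Statements on the series, on what has been measured and on what is new or still open speak of the compounds shown alone.

Measured compounds:
Compound 1 `O=C(CN1CCN(c2nnc(Cc3ccncc3)c3ccccc23)CC1)Nc1ccc(F)c(Cl)c1`: 4 nM
Compound 2 `COc1ccc(NC(=O)CN2CCN(c3nnc(Cc4ccccc4)c4ccccc34)CC2)cc1OC`: 32200 nM
Compound 3 `Cc1ccccc1NC(=O)CN1CCN(c2nnc(Cc3ccccc3)c3ccccc23)CC1`: 17300 nM

Within the data shown here, in a functional assay on MDA-MB-231 cells (Homo sapiens) for cytotoxicity, read by MTT assay, with a stated time of 72 h (a lower number here means a stronger inhibitor, a higher number a weaker inhibitor), compound 1 gives by far the lowest number of the three; compound 3 and compound 2 both sit far higher, and each differs from compound 1 in more than one place, so no single step links them to it. Among the measured compounds shown here, the only single-place step among the measured compounds is a 1.9-fold lower number from compound 2 to compound 3 (0.27 log units; within the scatter), a swap of the aryl group on the amide nitrogen that left the number essentially where it was.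

Compound 4 `Cc1ccc(F)cc1NC(=O)CN1CCN(c2nnc(Cc3ccncc3)c3ccccc23)CC1` is not yet measured. It differs from compound 1 as follows: 5-fluoro-2-methylphenyl in place of 3-chloro-4-fluorophenyl on an amide-type nitrogen. The amide aryl swap between compound 2 and compound 3 suggests that changing substituents on this ring need not move the number much, though that pair stands far from compound 1. A small loss, if anything, seems the likeliest outcome. Compound 4 is therefore expected to give 12 nM, with a range from 2.5 nM to 60 nM. This expectation amounts to a 3.0-fold higher number from compound 1 to compound 4 (0.48 log units; beyond the scatter).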

Compound 4, half-maximal inhibitory concentration: 6.4 nM
Estimate against measurement, compound 4: 1.9-fold (0.27 log units) above, within the range that was stated.
By their numbers in this assay, from the lowest: compounds 1 and 4 (each within the scatter of the next); then compounds 3 and 2 (each within the scatter of the next).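

In this assay, replacing 3-chloro-4-fluorophenyl with 5-fluoro-2-methylphenyl on the amide-type nitrogen gives a 1.6-fold higher number from compound 1 to compound 4 (0.20 log units; within the scatter), so this swap, in which chlorine leaves and a methyl group enters, makes no change that can be told from the scatter. Among these compounds, the only earlier step at this place linked two compounds with far higher numbers, whereas this one shows that a low number can also hold through a change of aryl substituents when the rest of compound 1 stays fixed. Nothing at hand explains why the number holds through this swap.

From the compounds shown here alone, whether the low number would survive an aryl ring carrying an amine or a carboxylic acid, or a butyl chain in place of the ring, remains open. Among the compounds shown here, no single step links compound 1 or compound 4 to compound 2 or compound 3, so the source of their far higher numbers also remains open.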